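Pyridyl Ether in Place of Fluorophenyl Ether

The source may report more compounds than this note shows. Statements on the series, on what has been measured and on what is new or still open speak of the compounds shown alone.

Compound 2 `C=CC(=O)NCc1coc(-c2c(N)ncnc2Nc2ccc(Oc3ccc(F)cc3)c(Cl)c2)n1` and compound 1 `C=CC(=O)NCc1coc(-c2c(N)ncnc2Nc2ccc(Oc3ccccc3)c(Cl)c2)n1` share the same core and differ in one place only. In an in vitro ADME assay on microsomes from liver (Homo sapiens) for metabolic stability, tested at 5 uM (a higher number here means that the compound lasts longer, a lower number that the compound disappears faster), compound 1 gives > 1.66 h, which is a limit of the measurement rather than a number. Compound 2 gives > 1.66 h in this assay, again a limit and not a number. Because both values sit at the same limit (the limit of > 1.66 h in this assay, at which 2 of the 2 values shown sit), the step that the two limits leave unreadable from compound 1 to compound 2 cannot be given a size. Compound 3 `C=CC(=O)NCc1coc(-c2c(N)ncnc2Nc2ccc(Oc3cccnc3)c(Cl)c2)n1` carries the change (pyridin-3-yl in place of 4-fluorophenyl on an oxygen on an aromatic ring). Within the data shown here, no measured step covers this exchange, and the single measured step is unreadable, so there is no footing for a direction. Compound 3 is therefore expected to move little, the step being an at least 1.1-fold lower number from compound 2 to compound 3 (0.04 log units; that floor lies within the scatter), with a fair chance that this assay once more reports only a limit. Compound 3 is estimated at 1.5 h, between 0.6 h and 3 h.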

Compound 3, half-life: 0.25 h
Compound 3: middle estimate off by 6.0-fold (0.78 log units), on the high side, and the stated range ends above it.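

In this assay, the position on the oxygen turns out to matter, which the earlier pair could not show, as its step cannot be read. Pyridin-3-yl in place of 4-fluorophenyl gives an at least 6.6-fold lower number from compound 2 to compound 3 (0.82 log units; beyond the scatter), and pyridin-3-yl in place of phenyl gives an at least 6.6-fold lower number from compound 1 to compound 3 (0.82 log units; beyond the scatter). Both steps lie beyond the scatter, so swapping one carbon-only aromatic ring for a ring with a hetero atom at this place shortens the half-life clearly, whether or not the leaving ring carries fluorine.

As far as these compounds go, how large the loss really is stays open, because the half-lives of the two carbon-only compounds are limits and both steps are therefore only floors: the limit of > 1.66 h in this assay, at which 2 of the 3 values shown sit. Also open is whether pyridin-4-yl or pyridin-2-yl on the same oxygen would shorten the half-life as much.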